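This account rests on a few compounds, and the source may have more. Where it says the series, first, only, none or still open, it means among the compounds named here.

In a functional assay on HepG2 cells (Homo sapiens) for inhibition, read by MTT assay, with a stated time of 72 h (on this read-out higher numbers stand for weaker inhibition and lower numbers for stronger inhibition), the measured compounds stand as follows.

Compound 1 `CN(C(=O)NC(=O)c1ccc(F)c(F)c1)c1nc(C(F)(F)F)c(C(=O)N/N=C/c2ccc(C(F)(F)F)cc2)s1`: compound 1 gives 6.26 ug/mL.
Compound 2 `CN(C(=O)NC(=O)c1ccc(C(F)(F)F)cc1)c1nc(C(F)(F)F)c(C(=O)N/N=C/c2ccc(C(F)(F)F)cc2)s1`: compound 2 gives only a limit of the assay, > 100 ug/mL.
Compound 3 `CN(C(=O)NC(=O)c1ccc(C(F)(F)F)cc1)c1nc(C(F)(F)F)c(C(=O)N/N=C/c2cccc(C(F)(F)F)c2)s1`: compound 3 gives 7.95 ug/mL.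

The value of compound 2 is the limit of > 100 ug/mL in this assay, at which 1 of the 3 values shown sits, so it is a limit and not a number. Two single changes lead away from compound 2. The first, (3,4-difluorophenyl in place of 4-(trifluoromethyl)phenyl on a carbonyl carbon), gives an at least 15-fold lower number from compound 2 to compound 1 (1.20 log units; beyond the scatter). The second changes the core: the core of compound 3 differs from the core of compound 2 by 3-(trifluoromethyl)phenyl in place of 4-(trifluoromethyl)phenyl on a carbon with a double bond to nitrogen, and this gives an at least 12-fold lower number from compound 2 to compound 3 (1.09 log units; beyond the scatter). Compound 1 and compound 3 lie within the usual scatter of each other.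

Compound 4 `CN(C(=O)NC(=O)c1ccc(F)c(F)c1)c1nc(C(F)(F)F)c(C(=O)N/N=C/c2cccc(C(F)(F)F)c2)s1` has not been measured in this assay. It differs from compound 3 by 3,4-difluorophenyl in place of 4-(trifluoromethyl)phenyl on a carbonyl carbon. For the measured compounds named here, this is the same change, at the same place, as the one from compound 2 to compound 1, where it gave an at least 15-fold lower number from compound 2 to compound 1 (1.20 log units; beyond the scatter). That earlier step started from a limit, so its true size is not known. Because compound 3 already gives 7.95 ug/mL, a measured number, a smaller step is expected here: a 2.0-fold lower number from compound 3 to compound 4 (0.30 log units; within the scatter). Compound 4 is therefore estimated at 4 ug/mL, with a likely range from 1 ug/mL to 12 ug/mL.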

Compound 4, half-maximal inhibitory concentration: 5.6 ug/mL
Compound 4: the middle estimate sits 1.4-fold (0.15 log units) below what was measured; measured number inside the range.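

In this assay, putting 3,4-difluorophenyl in place of 4-(trifluoromethyl)phenyl on the carbonyl carbon gives a 1.4-fold lower number from compound 3 to compound 4 (0.15 log units; within the scatter), so this change does not repeat on the new core what it did when it started from compound 2: the same change on two cores in this assay, an at least 15-fold lower number (1.20 log units; beyond the scatter) from compound 2 to compound 1 and a 1.4-fold lower number (0.15 log units; within the scatter) from compound 3 to compound 4, at least 11-fold (1.05 log units) apart, beyond the scatter of two such steps

Putting 3-(trifluoromethyl)phenyl in place of 4-(trifluoromethyl)phenyl on the carbon with a double bond to nitrogen gives a 1.1-fold lower number from compound 1 to compound 4 (0.05 log units; within the scatter), and this change, too, does not carry over at its earlier size: the same change on two cores in this assay, an at least 12-fold lower number (1.09 log units; beyond the scatter) from compound 2 to compound 3 and a 1.1-fold lower number (0.05 log units; within the scatter) from compound 1 to compound 4, at least 11-fold (1.05 log units) apart, beyond the scatter of two such steps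

Compound 2 gives > 100 ug/mL, which is a limit and not a number, so the pair of comparisons shows that the size of each change depends on the compound it starts from, but it does not show how large the steps from compound 2 really are.

The compounds shown leave open whether the values stay in this range when the ring on the carbonyl carbon carries a different kind of group, such as an amine or a carboxylic acid. They also leave open what happens when the trifluoromethyl group on the other ring gives way to a nitrile or a longer chain.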